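A few compounds are considered here, and "the series" means these few. Any claim that something is new, unique, unknown or untested is made for them only; others in the source may bear on it.

Measured compounds in a functional assay on the whole organism for inhibition, with Mus musculus as the target, at a dose of 1 mg/kg by the oral route; a lower number here means less inhibition, a higher number more inhibition at the dose given (going by the name of the read-out):
compound 1, `CCN(C(=O)c1c(O)c2c(C)cccc2n(C)c1=O)c1ccccc1`: 65%
compound 2, `CC(C)N(C(=O)c1c(O)c2c(Cl)cccc2n(C)c1=O)c1ccccc1`: 54%
compound 3, `CN(C(=O)c1c(O)c2c(C(F)(F)F)cccc2n(C)c1=O)c1ccccc1`: 99%

Compound 1 stands second highest of the three numbers in this assay. Its nearest neighbour is compound 2, whose reading in this assay is lower by a margin beyond the usual scatter; furthest away is compound 3, whose reading is higher, again by a margin beyond the scatter. No pair among these three differs in one place only, so no single step between measured compounds can be read off.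

The next compound, compound 4, is `CCN(C(=O)c1c(O)c2c(C(F)(F)F)cccc2n(C)c1=O)c1ccccc1`. It departs from compound 1 by trifluoromethyl in place of methyl on an aromatic carbon.

Compound 3 also carries a trifluoromethyl on its core and gives the highest number of the set, while compound 1 with methyl gives the middle one; these two values are all that is known for such a comparison, and they differ in more than one place. On that basis a rise is expected from compound 1 to compound 4, beyond the scatter, though the ceiling of the read-out limits how far it can go. The expected step is a number 20 percentage points higher from compound 1 to compound 4 (beyond the scatter).

For compound 4 in this assay the estimate is 85%, with a range from 65% to 99%.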

Compound 4, a percentage reported as inhibition, in the whole organism at one dose (the size of the read-out at that dose, not a potency): 80%
Estimate against measurement, compound 4: 5 percentage points above; low and high end bracket the measured number.
By their numbers in this assay, from the lowest: compound 2; then compound 1; then compound 4; then compound 3.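

In this assay, among these compounds, the aromatic carbon now has its first comparison in which only one place changes: trifluoromethyl in place of methyl gives a number 15 percentage points higher from compound 1 to compound 4 (beyond the scatter), so the change is a gain beyond the scatter in this single pair, with the ethyl group on the amide-type nitrogen held constant. Among the compounds shown here, the same new compound also gives the first one-place reading on the nitrogen side chain: with trifluoromethyl held constant, methyl in place of hydrogen on the saturated chain carbon gives a number 19 percentage points lower from compound 3 to compound 4 (beyond the scatter), so the chain extension costs inhibition here and the shorter chain reads higher. No supporting measurement bears on why either change has this result.

From the compounds shown here alone, whether the chain step holds with methyl on the aromatic carbon remains open, as does the size of the trifluoromethyl step with a methyl group on the amide-type nitrogen, and compound 2 differs from every other compound in more than one place, so it settles neither question. The compounds shown also leave open how a nitrile on the aromatic carbon or a butyl chain on the amide-type nitrogen would read.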